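The source may report more compounds than this note shows. Statements on the series, on what has been measured and on what is new or still open speak of the compounds shown alone.

Measured so far in a functional assay on A-431 cells (Homo sapiens) for antiproliferative activity, read by sulforhodamine B assay, with a stated time of 72 h; on this read-out higher numbers stand for weaker inhibition and lower numbers for stronger inhibition:
compound 1 `O=C(NCCN1CCCC1)Nc1cc2c(Nc3ccc(F)c(Cl)c3)ncnc2cc1O[C@H]1CCOC1` gives 247 nM;
compound 2 `COC(CCNC(=O)Nc1cc2c(Nc3ccc(F)c(Cl)c3)ncnc2cc1O[C@H]1CCOC1)OC` gives 22000 nM;
compound 3 `CN(C)CCCN(C)C(=O)Nc1cc2c(Nc3ccc(F)c(Cl)c3)ncnc2cc1O[C@H]1CCOC1` gives 200 nM.

Compound 3 has the lowest of the three numbers, with compound 1 so close that the two cannot be told apart, while compound 2 lies far away. Compound 4 `CN1CCN(C(=O)Nc2cc3c(Nc4ccc(F)c(Cl)c4)ncnc3cc2O[C@H]2CCOC2)CC1` differs from compound 3 in one place: 4-methylpiperazin-1-yl in place of (3-(dimethylamino)propyl)(methyl)amino on a carbonyl carbon. Two earlier steps speak to this change. Exchanging one amine-bearing side group for another left the number unchanged within the scatter (a 1.2-fold lower number from compound 1 to compound 3 (0.09 log units; within the scatter)), whereas replacing the amine-bearing group of compound 3 by a dimethoxy-bearing one gave a large rise (a 110-fold lower number from compound 2 to compound 3 (2.04 log units; beyond the scatter), read in reverse). Compound 4 keeps an amine-bearing ring on the carbonyl, so the step of a 1.5-fold higher number from compound 3 to compound 4 (0.18 log units; within the scatter) is expected to stay within the scatter. Compound 4 is therefore estimated at 300 nM, between 120 nM and 800 nM.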

Compound 4, half-maximal inhibitory concentration: 675 nM
Estimate against measurement, compound 4: 2.3-fold (0.35 log units) below, and the stated range covers the measured number.
By their numbers in this assay, from the lowest: compounds 3 and 1 (each within the scatter of the next); then compound 4; then compound 2.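

In this assay, the 4-methylpiperazin-1-yl ring on the carbonyl carbon gives a 3.4-fold higher number from compound 3 to compound 4 (0.53 log units; beyond the scatter) and a 2.7-fold higher number from compound 1 to compound 4 (0.44 log units; beyond the scatter) as well, so amine-bearing groups here are not all interchangeable, as compound 1 and compound 3 alone had suggested. The ring still stands far from the (3,3-dimethoxypropyl)amino group, with a 33-fold lower number from compound 2 to compound 4 (1.51 log units; beyond the scatter) in its favour. No measurement here explains these steps. Still open, going by these compounds, is whether the ring itself or its methyl group sets the number, which an unsubstituted piperazine or a morpholine ring on the same carbonyl carbon could help separate.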